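A Benzimidazole Replaces a Fluorophenyl Group

The source may report more compounds than this note shows. Statements on the series, on what has been measured and on what is new or still open speak of the compounds shown alone.

Compound 1 `COc1ccc(CN(c2cc(OC)c(OC)c(OC)c2)S(=O)(=O)c2ccccc2)cc1`: in a functional assay on PC-3 cells (Homo sapiens) for inhibition, read by MTT assay, with a stated time of 48 h (a higher number here means a weaker inhibitor, a lower number a stronger inhibitor), compound 1 reaches only the assay's limit, > 50000 nM.
Compound 2 `COc1ccc(CN(c2cc(OC)c(OC)c(OC)c2)S(=O)(=O)c2c(C)cc(C)cc2C)cc1`: in this assay compound 2 gives 14800 nM.
Compound 3 `COc1cc(N(Cc2ccc(F)cc2)S(=O)(=O)c2ccc(C)cc2)cc(OC)c1OC`: in this assay compound 3 gives 20700 nM.

Within the data shown here, of the two plain numbers reported, the one for compound 3 is the higher, yet its gap to compound 2 lies within the usual scatter, so the two cannot really be told apart. Compound 4 `COc1cc(N(Cc2nc3ccccc3[nH]2)S(=O)(=O)c2ccc(C)cc2)cc(OC)c1OC` has not yet been measured. It differs from compound 3 in one place: 1H-benzimidazol-2-yl in place of 4-fluorophenyl on a saturated chain carbon bound to a sulfonamide nitrogen.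

Among the measured compounds shown here, the only single-point step measured so far is an at least 3.3-fold lower number from compound 1 to compound 2 (0.52 log units; beyond the scatter), and it concerns the group on the sulfonyl sulfur, not the group on the chain carbon. That step rests on compound 1 sitting at a limit, (the limit of > 50000 nM in this assay, at which 1 of the 3 values shown sits). Compounds 2 and 3 differ in two places at once, and their values lie within the scatter of each other, so they say nothing about either change alone.

For the measured compounds named here, no measured step touches the group that changes between compound 3 and compound 4, so the expected step of a 1.0-fold lower number from compound 3 to compound 4 (0.01 log units; within the scatter) is none beyond the scatter. Compound 4 is therefore estimated at 20000 nM in this assay, with a range from 6000 nM to 60000 nM.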

Compound 4, half-maximal inhibitory concentration: 3340 nM
For compound 4 the middle estimate is 6.0-fold (0.78 log units) above the measured one, outside the stated range (below it).
By their numbers in this assay, from the lowest: compound 4; then compounds 2 and 3 (each within the scatter of the next). At a limit, above all of these: compound 1.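

Among these compounds, until now no measured step touched the group on a saturated chain carbon bound to a sulfonamide nitrogen, and in this assay replacing 4-fluorophenyl with 1H-benzimidazol-2-yl gives a 6.2-fold lower number from compound 3 to compound 4 (0.79 log units; beyond the scatter), so the number at this position does respond to the group placed there. This step lies beyond the scatter and is modest in size, and unlike the earlier step on the sulfonyl sulfur, it rests on two plain numbers rather than on a limit of the assay. The swap adds a five-membered aromatic ring with 2 hetero atoms, a hydrogen-bond donor and a hydrogen-bond acceptor all at once, and nothing measured here explains the lower number or separates these parts.

The compounds shown leave open which part of the benzimidazole counts, a question that an indol-2-yl group or a 1-methylbenzimidazol-2-yl group at this position could help to settle. They also leave open whether the same swap would lower the number to a similar degree with 2,4,6-trimethylphenyl on the sulfonyl sulfur in place of the group carried by compound 4.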